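Fluoro for Trifluoromethyl on the Aryl Triazole Arm

A few compounds are considered here, and "the series" means these few. Any claim that something is new, unique, unknown or untested is made for them only; others in the source may bear on it.

The set rests on a shared core carrying a triazole-linked aryl group, read in a functional assay on A549 cells (Homo sapiens) for cytotoxicity, read by MTT assay, with a stated time of 4 days; on this read-out higher numbers stand for weaker inhibition and lower numbers for stronger inhibition. Compound 1 `Cc1c(O)ccc2c1[C@H](Cn1cc(-c3ccc(F)cc3)nn1)[C@@]13CC(=O)[C@@](C)(CC[C@@H]21)C3` gives > 20000 nM in this assay, a limit of the measurement rather than a number. Compound 2 `C=C1C[C@]23C[C@@]1(O)CC[C@H]2c1ccc(O)c(C)c1[C@@H]3Cn1cc(-c2ccc(C(F)(F)F)cc2)nn1` gives 10400 nM in this assay, the higher of the two numbers recorded. Among the measured compounds shown here, compound 3 `C=C1C(=O)[C@]23C[C@@]1(O)CC[C@H]2c1ccc(O)c(C)c1[C@@H]3Cn1cc(-c2ccc(C)cc2)nn1` gives 1260 nM in this assay, and the gap between compound 3 and compound 2 lies beyond the usual scatter; compound 3 differs from compound 2 in more than one place, so no single step between them is counted.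

Compound 4 `C=C1C[C@]23C[C@@]1(O)CC[C@H]2c1ccc(O)c(C)c1[C@@H]3Cn1cc(-c2ccc(F)cc2)nn1` is not yet measured. It differs from compound 2 only in one place: fluoro in place of trifluoromethyl on an aromatic carbon. For the measured compounds named here, no step within the measured compounds isolates this change, and compound 1, which carries the same 4-fluorophenyl group on a different core, sits only at a limit. The step from compound 2 to compound 4 is therefore expected to be small, likely within the scatter, with a lean toward a higher number, as a 1.4-fold higher number from compound 2 to compound 4 (0.16 log units; within the scatter). Compound 4 is estimated at 15000 nM in this assay, between 5000 nM and 40000 nM.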

Compound 4, half-maximal inhibitory concentration: > 20000 nM
Compound 4 ended at the assay's limit; the forecaster's own chance of this, stated with the estimate: 35%; middle value at least 1.3-fold (0.12 log units) away from the limit.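

On the shared core of compound 2, the change from 4-(trifluoromethyl)phenyl to 4-fluorophenyl now has a reading of its own, an at least 1.9-fold higher number from compound 2 to compound 4 (0.28 log units; that floor lies within the scatter) in this assay, and this position is the only place in which the two compounds differ. In that assay compound 4 gives > 20000 nM, which is a limit and not a number. The step is therefore known only as a floor, and the top of the assay's range now bounds the reading at this position as well: the limit of > 20000 nM in this assay, at which 2 of the 4 values shown sit.

Going by these compounds, whether the true step from trifluoromethyl to fluoro lies beyond the scatter remains open. Also open, on these data alone, is how an amine or a carboxylic acid on this aromatic carbon would read on the same core.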